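Piperidin-1-yl for dimethylamino on the side chain

The source may hold more compounds than are shown below. What is called first, only, known or untested is meant among the compounds shown, and "the series" means these compounds.

Measured in a functional assay on A549 cells (Homo sapiens) for antiproliferative activity, read by MTT assay, with a stated time of 72 h; a lower number here means a stronger inhibitor, a higher number a weaker inhibitor:
- Compound 1 `COc1cc2c(Nc3ccc(C#N)cc3)ncnc2cc1OCCCN(C)C`: 60500 nM
- Compound 2 `COc1cc2c(Nc3ccc(C#N)cc3)ncnc2cc1OCCCN(C)Cc1ccccc1`: > 100000 nM (a limit of the assay)

For the measured compounds named here, compound 1 holds the only actual number so far in this assay, with 60500 nM as its reading. The one other result is a limit and not a number: compound 2 reads > 100000 nM here.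

Compound 3 `COc1cc2c(Nc3ccc(C#N)cc3)ncnc2cc1OCCCN1CCCCC1` carries piperidin-1-yl in place of dimethylamino on a saturated chain carbon, three bonds along the chain from an oxygen on an aromatic ring.

Going by the values given here, only one measured step bears on this change, and it also falls at the amine end of the chain: an at least 1.6-fold higher number from compound 1 to compound 2 (0.21 log units; that floor lies within the scatter), with phenyl in place of hydrogen on a saturated chain carbon bound to an amine nitrogen. That step gives a floor and not a size, so it supports no direction for the new change. No shift beyond the scatter is therefore expected in this assay.

The expected step is a 1.0-fold lower number from compound 1 to compound 3 (0.00 log units; within the scatter).

The estimated value for compound 3 is 60000 nM, with an expected range from 22000 nM to 100000 nM.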

Compound 3, half-maximal inhibitory concentration: 23500 nM
Beside the measured number, compound 3's estimate is 2.6-fold (0.41 log units) above it; low and high end bracket the measured number.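

In this assay, for the compounds shown here, the amine end of the side chain now gives a first step beyond the scatter: a 2.6-fold lower number from compound 1 to compound 3 (0.41 log units; beyond the scatter), with piperidin-1-yl in place of dimethylamino on a saturated chain carbon, three bonds along the chain from an oxygen on an aromatic ring. Replacing benzyl(methyl)amino with piperidin-1-yl gives an at least 4.2-fold lower number from compound 2 to compound 3 (0.62 log units; beyond the scatter), and the size of this step is only a floor: the limit of > 100000 nM in this assay, at which 1 of the 3 values shown sits. Compound 3 therefore has the lowest number of the three, showing that this position responds to the choice of amine, which the earlier step, with its floor within the scatter, could not show.

The compounds shown do not separate the effect of the ring from that of the larger group, and pyrrolidin-1-yl or morpholin-4-yl at the same place would bear on this. Going by these compounds, it also remains open whether the step holds on another chain, such as 2-(piperidin-1-yl)ethyl, and how large the true gap to compound 2 is.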